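The compounds below may be only part of what the source reports. "The series", "measured", "known", "first", "only" and "open" are said of these compounds alone.

Compound 1, `COc1ccc(-c2nc3cc(/C(C)=N/O)ccc3[nH]2)c(OC)c1`: in an ADME assay on MDBK cells (Bos taurus) for cytotoxicity, read by MTT assay, with a stated time of 96 h (a lower number here means that less compound is tolerated, a higher number that more compound is tolerated), compound 1 gives > 100000 nM, which is a limit of the assay rather than a number.
Compound 2, `COc1ccc(-c2nc3cc(/C(C)=N/O)ccc3[nH]2)c(OC)c1OC`: in this assay compound 2 gives > 100000 nM, again a limit.
Compound 3, `COc1ccc(-c2nc3cc(C(C)=O)ccc3n2C2CCCCC2)cc1`: in this assay compound 3 gives > 100000 nM, again a limit.

From compound 1 to compound 2 the change is methoxy in place of hydrogen on an aromatic carbon. The step it made is a step that the two limits leave unreadable from compound 1 to compound 2. Compound 3 has a different core, and the difference between the two cores is not broken down here.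

Compound 4, `COc1ccc(-c2nc3cc(C(C)=O)ccc3n2C2CCCCC2)c(OC)c1`, is not yet measured. It differs from compound 3 by methoxy in place of hydrogen on an aromatic carbon. This is the same kind of change as from compound 1 to compound 2, but the surroundings differ: in compound 4 the new group sits ortho to a large group and meta to a methoxy group, whereas in compound 2 it sits ortho to two methoxy groups and meta to a large group.

All measured values sit at the limit of > 100000 nM in this assay, at which 3 of the 3 values shown sit. Beside the earlier step, the expected step is a number no higher from compound 3 to compound 4 (the limit leaves the size open), and this expectation rests on (the limit of > 100000 nM in this assay, at which 3 of the 3 values shown sit). Compound 4 is expected to give 100000 nM, between 40000 nM and 300000 nM.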

Compound 4, half-maximal cytotoxic concentration: 21000 nM
For compound 4 the middle estimate is 4.8-fold (0.68 log units) above the measured one; the whole stated range lies above it.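

In this assay, methoxy in place of hydrogen on an aromatic carbon gave an at least 4.7-fold lower number from compound 3 to compound 4 (0.67 log units; beyond the scatter), so on the core of compound 3, with the new group ortho to a large group and meta to a methoxy group, less compound is tolerated once this group is present. For the compounds shown here, the same kind of change from compound 1 to compound 2 cannot be read, as both ends of that step are limits of the assay rather than numbers, and most of the series shares this ceiling: the limit of > 100000 nM in this assay, at which 3 of the 4 values shown sit. Only one readable step therefore exists, which shows that the change can lower the number on one core but does not show whether the effect carries over to the core of compound 1 or any other core.

The compounds shown leave open whether an amine, a carboxylic acid or a longer chain at the same place would lower the number as methoxy does. Going by these compounds, the full size of the step also stays open, as only its lower bound can be read.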